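Removing one aryl methoxy: compound 2 to compound 4

The compounds below may be only part of what the source reports. "The series", "measured", "known", "first", "only" and "open" are said of these compounds alone.

Measured so far in a functional assay on U-87MG ATCC cells for antiproliferative activity against U-87 MG (Homo sapiens), read by MTT assay, with a stated time of 48 h, tested at 5 uM; a lower number here means a stronger effect, a higher number a weaker effect of the compound at the concentration tested:
compound 1 `COc1ccc(-c2nc(SCC(=O)c3sc(-c4ccccc4)nc3C)[nH]c(=O)c2C#N)cc1` gives 97.3%
compound 2 `COc1ccc(-c2nc(C)c(C(=O)CSc3nc(-c4ccc(OC)cc4)c(C#N)c(=O)[nH]3)s2)cc1` gives 97%
compound 3 `COc1ccc(-c2nc(SCC(=O)c3sc(-c4ccc(Cl)cc4)nc3C)[nH]c(=O)c2C#N)cc1` gives 92.1%

All three numbers sit close together at the high end of the scale. Compound 2 stands second highest of the three: its nearest neighbour is compound 1, a number 0.3 percentage points lower from compound 1 to compound 2 (within the scatter), and its furthest is compound 3, a number 4.9 percentage points lower from compound 2 to compound 3 (within the scatter). Neither gap exceeds the scatter, so no order among the three can be claimed.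

Compound 4 `COc1ccc(-c2nc(C)c(C(=O)CSc3nc(-c4ccccc4)c(C#N)c(=O)[nH]3)s2)cc1` has not yet been measured. It differs from compound 2 as follows: hydrogen in place of methoxy on an aromatic carbon. Among the measured compounds shown here, two measured steps bear on this change. The step from compound 1 to compound 2 is the same exchange run the other way, set on a different aromatic carbon of the shared core, and was within the scatter; the step from compound 2 to compound 3 replaces the same methoxy by chloro and was likewise within the scatter. Nothing here points to a step beyond the scatter, so compound 4 is expected to give 96% in this assay, in the range 89% to 100%, which means an estimated a number 1 percentage points lower from compound 2 to compound 4 (within the scatter).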

Compound 4, a percentage reported as activity, at one concentration (the size of the read-out at that concentration, not a potency): 99%
Compound 4: middle estimate off by 3 percentage points, on the low side, and the stated range covers the measured number.
By their numbers in this assay, from the lowest: compounds 3, 2, 1 and 4 (each within the scatter of the next).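

Among the compounds shown here, compounds 1, 2 and 3 all kept the 4-methoxyphenyl group at this position and varied only the other aromatic ring, so this is the first reading of a change here. In this assay, going from 4-methoxyphenyl to phenyl gives a number 2 percentage points higher from compound 2 to compound 4 (within the scatter), so the methoxy at this carbon, para to a large group, can be lost without a step beyond the scatter, as with the same exchange on the other aromatic ring, read in the opposite direction as a number 0.3 percentage points lower from compound 1 to compound 2 (within the scatter). No measurement available here bears on why this position tolerates the change.

As far as these compounds go, whether any replacement at this carbon moves the read-out beyond the scatter remains open, for example an amine or a carboxylic acid. The compounds shown also leave open how a group of either kind would read at other concentrations.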